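This account rests on a few compounds, and the source may have more. Where it says the series, first, only, none or still open, it means among the compounds named here.

Measured compounds:
compound 1, `COc1cc[nH]c1/C=C1/C(=O)Nc2ccc(F)cc21`: > 30000 nM
compound 2, `COc1cc[nH]c1/C=C1\C(=O)Nc2ccc(F)c(C#CC(O)CN)c21`: 130 nM
compound 3, `COc1cc[nH]c1/C=C1\C(=O)Nc2ccc(F)c(C#C[C@H](N)CO)c21`: 320 nM

In a functional assay on MDA-MB-435 cells (Homo sapiens) for inhibition (on this read-out lower numbers stand for stronger inhibition and higher numbers for weaker inhibition), compound 1 reaches only a limit, > 30000 nM. Among the two numbers, compound 3 has the higher one; the single measured step, a 2.5-fold higher number from compound 2 to compound 3 (0.39 log units; beyond the scatter), separates it from compound 2. Compound 4, `CCN[C@H](C#Cc1c(F)ccc2c1/C(=C/c1[nH]ccc1OC)C(=O)N2)CO`, is not yet measured; it differs from compound 3 by 1-(ethylamino)-2-hydroxyethyl in place of 1-amino-2-hydroxyethyl on a triple-bonded carbon. Among the measured compounds shown here, no measured step bears on this change: the only one recorded concerns the arrangement of amine and hydroxyl, not alkylation of the amine. The step is therefore expected to stay within the scatter, a 1.1-fold lower number from compound 3 to compound 4 (0.03 log units; within the scatter). The estimate for compound 4 in this assay is 300 nM, in the range 100 nM to 1000 nM.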

Compound 4, half-maximal inhibitory concentration: 1160 nM
Estimate against measurement, compound 4: 3.9-fold (0.59 log units) below, and the stated range ends below it.
By their numbers in this assay, from the lowest: compound 2; then compound 3; then compound 4. At a limit, above all of these: compound 1.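

In this assay, adding ethyl to the amine gives a 3.6-fold higher number from compound 3 to compound 4 (0.56 log units; beyond the scatter), showing that the 3-(ethylamino)-4-hydroxybut-1-yn-1-yl chain on this triple-bonded carbon responds to substitution at the nitrogen, not only to the arrangement of amine and hydroxyl. Measured against the other arrangement, the result is an 8.9-fold higher number from compound 2 to compound 4 (0.95 log units; beyond the scatter), the widest gap among the compounds with numbers. Nothing in the data shown explains this change. On these data alone, whether a methyl or propyl group on the amine would behave like ethyl remains open, as does the effect of ethyl on the 2-amino-1-hydroxyethyl chain of compound 2.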